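Isopropoxy in Place of Propylamino: Estimating Compound 4

The source may report more compounds than this note shows. Statements on the series, on what has been measured and on what is new or still open speak of the compounds shown alone.

Measured so far:
compound 1 `CCOC(=O)C(=O)Nc1cccc(N)c1C#N`: 0.05 mg/kg
compound 2 `CCNc1cccc(NC(=O)C(=O)OCC)c1C#N`: 0.03 mg/kg
compound 3 `CCCNc1cccc(NC(=O)C(=O)OCC)c1C#N`: 0.5 mg/kg

All three were tested in a functional assay on the whole organism with Rattus norvegicus as the target; on this read-out lower numbers stand for an effect already at smaller amounts and higher numbers for an effect only at larger amounts of compound. Compound 3 gives the highest number of the three; the steps of a 10-fold higher number from compound 1 to compound 3 (1.00 log units; beyond the scatter) and a 17-fold higher number from compound 2 to compound 3 (1.22 log units; beyond the scatter) both lie beyond the scatter, so compound 3 is the least potent compound measured. Compound 1 and compound 2 sit within the scatter of each other, as a 1.7-fold lower number from compound 1 to compound 2 (0.22 log units; within the scatter) shows.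

Compound 4 `CCOC(=O)C(=O)Nc1cccc(OC(C)C)c1C#N` differs from compound 3 in one place: isopropoxy in place of propylamino on an aromatic carbon. For the measured compounds named here, no measured step exchanges the nitrogen of this substituent for an oxygen, so nothing bears directly on the change. The steps at the same place, a 10-fold higher number from compound 1 to compound 3 (1.00 log units; beyond the scatter) and a 17-fold higher number from compound 2 to compound 3 (1.22 log units; beyond the scatter), only show that a propyl chain on that nitrogen raised the number, while an ethyl chain left it within the scatter. From the compounds shown here alone, whether removing the nitrogen and its hydrogen-bond donor reverses that rise is unknown, so the expectation is wide. Compound 4 is expected to give 0.2 mg/kg, with a range from 0.03 mg/kg to 1.5 mg/kg. The expected step is a 2.5-fold lower number from compound 3 to compound 4 (0.40 log units; beyond the scatter), leaning toward a lower number but with little confidence in its direction.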

Compound 4, dose for half-maximal effect: 2 mg/kg
Compound 4: the middle estimate sits 10-fold (1.00 log units) below what was measured, outside the stated range (above it).
By their numbers in this assay, from the lowest: compounds 2 and 1 (each within the scatter of the next); then compound 3; then compound 4.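

In this assay, isopropoxy in place of propylamino gives a 4.0-fold higher number from compound 3 to compound 4 (0.60 log units; beyond the scatter) and so does not undo the rise that came with the propyl chain on the nitrogen. The gap to the compounds with smaller groups on that aromatic carbon is wider, with a 67-fold higher number from compound 2 to compound 4 (1.82 log units; beyond the scatter) and a 40-fold higher number from compound 1 to compound 4 (1.60 log units; beyond the scatter) both beyond the scatter. That makes compound 4 the least potent of the four, and the series now shows that a nitrogen-linked group is not needed for a measurable effect at this position, although the one oxygen-linked group shown gives the highest number.

This change replaces the nitrogen with oxygen and also swaps a straight chain for a branched one, so an isopropylamino or propoxy group would be needed to tell the two apart. Nothing available explains the direction or size of this step.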